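This account rests on a few compounds, and the source may have more. Where it says the series, first, only, none or still open, it means among the compounds named here.

The shared core of these compounds is the one seen in compound 1 `CCCc1cc(N)c2cc(NC(=O)/C=C/c3ccc(Cl)cc3Cl)ccc2n1`, which in a functional assay on HEK293 cells for activation of melanin-concentrating hormone receptor 1 (Homo sapiens), read by inositol phosphate accumulation (a higher number here means that more compound is needed for the effect, a lower number that less compound is needed), gives 904 nM. Compound 2 `CCCc1cc(N)c2cc(NC(=O)/C=C/c3ccc(F)cc3)ccc2n1` carries a 4-fluorophenyl on the double-bonded chain and gives 200 nM in this assay. Compound 3 `CC(C)c1cc(N)c2cc(NC(=O)/C=C/c3ccc(C(F)(F)F)cc3)ccc2n1` differs from compound 2 in two places. In this assay compound 3 gives 160 nM, a number within the scatter of that of compound 2. Among the three numbers measured, compound 2 stands second highest, with compound 1 as the furthest and compound 3 as the nearest. Compound 4 `CCCc1cc(N)c2cc(NC(=O)/C=C/c3ccc(C(C)(C)C)cc3)ccc2n1` is not yet measured. Its change from compound 2 is tert-butyl in place of fluoro on an aromatic carbon. For the measured compounds named here, the only single-point step measured, a 4.5-fold lower number from compound 1 to compound 2 (0.66 log units; beyond the scatter), concerns a different exchange of substituents on the same aromatic ring and is of modest size; no measured pair puts a tert-butyl in place of a fluoro. Compound 3, with its 160 nM, shows that a trifluoromethyl in place of the fluoro, together with its second change, can sit at a number like that of compound 2. Compound 4 is therefore expected to show a step of a 1.3-fold lower number from compound 2 to compound 4 (0.10 log units; within the scatter), which is within the scatter, in this assay. The estimate for compound 4 is 160 nM, with a range from 50 nM to 500 nM.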

Compound 4, half-maximal effective concentration: 910 nM
Estimate against measurement, compound 4: 5.7-fold (0.75 log units) below; measured number above the stated range.
By their numbers in this assay, from the lowest: compounds 3 and 2 (each within the scatter of the next); then compounds 1 and 4 (each within the scatter of the next).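

In this assay, for the compounds shown here, tert-butyl in place of fluoro on this aromatic carbon gives a 4.6-fold higher number from compound 2 to compound 4 (0.66 log units; beyond the scatter), the first measured step in which this one group alone is exchanged. It shows that the number responds to the group at this carbon, even though neither the fluoro nor the tert-butyl carries a hydrogen-bond donor, a hydrogen-bond acceptor or a net charge; the change is one from a group of 1 heavy atom to one of 4 heavy atoms. Together with a 4.5-fold lower number from compound 1 to compound 2 (0.66 log units; beyond the scatter), which concerns the same ring, it places compound 2 lower in both single-point steps measured, but nothing measured here explains why the number moves with this exchange.

The compounds shown do not tell whether a methyl, a chloro or a methoxy at this carbon would give a number like that of compound 2 or like that of compound 4. They also leave open how an amine or a carboxylic acid would behave there, and what trifluoromethyl does on its own, since compound 3 carries it together with a second change.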